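This account rests on a few compounds, and the source may have more. Where it says the series, first, only, none or still open, it means among the compounds named here.

Measured so far:
- compound 1, `Oc1cccc(-c2cc(-c3ccoc3)cc(-c3ccccc3O)n2)c1`: > 50000 nM
- compound 2, `Oc1ccccc1-c1cc(-c2ccccn2)cc(-c2ccccc2O)n1`: > 50000 nM

Neither value in a functional assay on HCT-15 cells (Homo sapiens) for cytotoxicity, read by CCK-8 assay (a lower number here means a stronger inhibitor, a higher number a weaker inhibitor), is a number. Compound 1 reaches only a limit of the assay, > 50000 nM. Compound 2 likewise reaches only a limit, > 50000 nM. Compound 2 therefore stands nowhere within the measurable range; it sits at the limit of > 50000 nM in this assay, at which 2 of the 2 values shown sit, together with every other value shown. Among the compounds with values here, no pair of measured compounds differs in a single place, so no measured step size is available.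

Compound 3, `Oc1cccc(-c2cc(-c3ccccn3)cc(-c3ccccc3O)n2)c1`, is the next entry. Its difference from compound 2 is 3-hydroxyphenyl in place of 2-hydroxyphenyl on an aromatic carbon. The expected step of a number no higher from compound 2 to compound 3 (the limit leaves the size open) is none beyond the scatter, because the limit of > 50000 nM in this assay, at which 2 of the 2 values shown sit, is where both measured compounds sit and the exchange of one hydroxyphenyl for another leaves the rest of the molecule unchanged. Compound 3 is estimated at 50000 nM, within 20000 nM to 150000 nM, most probably reported again as a limit.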

Compound 3, half-maximal inhibitory concentration: > 50000 nM
Compound 3: only a limit was reported; the forecaster's own chance of this, stated with the estimate: 80%; the middle value lies on the limit itself.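

No step can be read from compound 2 to compound 3 or from compound 1 to compound 3, because each compound reaches only a limit, not a number: the limit of > 50000 nM in this assay, at which 3 of the 3 values shown sit.

The compounds shown leave open whether any change to the shared core brings a value within the measurable range.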